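Swapping the amide aryl group on a shared sulfonamide core

The compounds below may be only part of what the source reports. "The series", "measured", "known", "first", "only" and "open" are said of these compounds alone.

Compound 1 `COc1cccc(C(=O)NCc2ccc(CNS(=O)(=O)c3ccc(C)cc3)cc2)c1` gives 10 nM in an assay on MDA-MB-231 cells for binding affinity to C-X-C chemokine receptor type 4 (Homo sapiens), read by immunofluorescence and microscopy, with stated times of 10 min and 30 min; on this read-out lower numbers stand for an effect already at smaller amounts and higher numbers for an effect only at larger amounts of compound.
Compound 2 `Cc1ccc(S(=O)(=O)NCc2ccc(CNC(=O)c3ccc(Cl)cc3)cc2)cc1` gives 10 nM in this assay.
Compound 3 `COc1cccc(C(=O)NCc2ccc(CNS(=O)(=O)c3ccccc3)cc2)c1` gives > 1000 nM in this assay, which is a limit of the assay and not a number.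

The change 4-chlorophenyl in place of 3-methoxyphenyl on a carbonyl carbon gives no change at the digits printed from compound 1 to compound 2 (within the scatter). The cores of compound 1 and compound 3 differ by hydrogen in place of methyl on an aromatic carbon, and this gives an at least 100-fold higher number from compound 1 to compound 3 (2.00 log units; beyond the scatter), with compound 3 sitting at the limit of > 1000 nM in this assay, at which 1 of the 3 values shown sits.

Compound 4 `O=C(NCc1ccc(CNS(=O)(=O)c2ccccc2)cc1)c1ccc(Cl)cc1` has not been measured. It differs from compound 3 by 4-chlorophenyl in place of 3-methoxyphenyl on a carbonyl carbon, the same change as from compound 1 to compound 2, made on the same place. Since that change gave no change at the digits printed from compound 1 to compound 2 (within the scatter), the step that the limit leaves unreadable from compound 3 to compound 4 is expected to be small. Because compound 3 itself shows only > 1000 nM, compound 4 is estimated at 3000 nM, most likely again reported as a limit.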

Compound 4, effective concentration (reported as EC, without a stated level of effect): 100 nM
The estimate for compound 4 lay 30-fold (1.48 log units) above the measured number, outside the stated range (below it).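

On the core without the methyl, the change to 4-chlorophenyl gives an at least 10-fold lower number from compound 3 to compound 4 (1.00 log units; beyond the scatter), so the flat result seen on the methyl-bearing core does not carry over: the same change on two cores in this assay, no change at the digits printed (within the scatter) from compound 1 to compound 2 and an at least 10-fold lower number (1.00 log units; beyond the scatter) from compound 3 to compound 4, at least 10-fold (1.00 log units) apart, beyond the scatter of two such steps. Hydrogen in place of methyl gives a 10-fold higher number from compound 2 to compound 4 (1.00 log units; beyond the scatter) on the 4-chlorophenyl amide, and this step also differs from the one on the 3-methoxyphenyl amide: the same change on two cores in this assay, an at least 100-fold higher number (2.00 log units; beyond the scatter) from compound 1 to compound 3 and a 10-fold higher number (1.00 log units; beyond the scatter) from compound 2 to compound 4, at least 10-fold (1.00 log units) apart, beyond the scatter of two such steps. Compound 3 gives > 1000 nM, a limit of the assay and not a number, and these few pairs do not show why the steps differ or how either change behaves on further cores.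

Still open, going by these compounds, is how a longer chain in place of the methyl would read in this assay. The same applies to an amine or a carboxylic acid in place of the 4-chlorophenyl.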